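Pyridinyl for Fluoromethoxyphenyl: Outlook for Intrinsic Activity

A few compounds are considered here, and "the series" means these few. Any claim that something is new, unique, unknown or untested is made for them only; others in the source may bear on it.

Two measured compounds anchor this account. Compound 1 `C[C@@H]1CN(c2cc(NS(=O)(=O)c3ccc(-c4ccccn4)s3)ccc2C#N)C[C@H](C)N1` reaches 0.9 in a functional assay for agonist activity at growth hormone secretagogue receptor type 1 (Homo sapiens), read by FLIPR; on this read-out lower numbers stand for smaller maximal responses and higher numbers for larger maximal responses. Compound 2 `COc1ccc(F)c(-c2ccc(S(=O)(=O)Nc3cc(N4C[C@@H](C)N[C@@H](C)C4)ccc3OC)cc2)c1` reaches 1.2 in this assay, the higher of the two values, standing beyond the scatter from compound 1. The unmeasured compound 3 `COc1ccc(N2C[C@@H](C)N[C@@H](C)C2)cc1NS(=O)(=O)c1ccc(-c2ccncc2)cc1` differs from compound 2 in a single place: pyridin-4-yl in place of 2-fluoro-5-methoxyphenyl on an aromatic carbon. Among the compounds with values here, no measured pair shows this same change, so its effect can only be judged from the two values at hand, both of which sit at or past the reference response. Compound 3 is therefore expected to keep a large maximal response, with a step no larger than a number 0.20 lower from compound 2 to compound 3 (beyond the scatter), probably a mild easing rather than a gain. In this assay compound 3 is estimated at 1, within a range of 0.8 to 1.2.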

Compound 3, intrinsic activity: the largest response reached, as a fraction of the reference agonist's: 0.7
For compound 3 the middle estimate is 0.30 above the measured one; the measured number lies below the stated range.
By their numbers in this assay, from the lowest: compound 3; then compound 1; then compound 2.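

At this place, on an aromatic carbon para to a large group, the choice of aromatic group clearly bears on the maximal response: in this assay, pyridin-4-yl in place of 2-fluoro-5-methoxyphenyl gives a number 0.50 lower from compound 2 to compound 3 (beyond the scatter). This is the only one-place step among the compounds shown, and the drop comes with no change in the counts of hydrogen-bond donors and acceptors, while the group shrinks from 9 heavy atoms to 6. No measurement shown here accounts for the size of this step.

On these data alone, it remains open whether the step follows the ring nitrogen or the loss of the fluorine and methoxy substituents. Plain phenyl or pyridin-3-yl at this place would be the groups to separate these readings.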